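The source may hold more compounds than are shown below. What is called first, only, known or untested is meant among the compounds shown, and "the series" means these compounds.

Compound 3 `COc1ccc2c(-c3cc(C(F)(F)F)cc(-c4cn(S(=O)(=O)c5ccc(C)cc5)c5cc(OC)ccc45)n3)cn(S(=O)(=O)c3ccc(C)cc3)c2c1` and compound 1 `COc1ccc2c(-c3cc(C(F)(F)F)c(C#N)c(-c4cn(S(=O)(=O)c5ccc(C)cc5)c5cc(OC)ccc45)n3)cn(S(=O)(=O)c3ccc(C)cc3)c2c1` share one core; compound 1 carries the change (cyano in place of hydrogen on an aromatic carbon). In a functional assay on A549 cells (Homo sapiens) for inhibition, tested at 1 uM (a lower number here means a weaker effect, a higher number a stronger effect of the compound at the concentration tested), compound 3 gives 35.5%, and compound 1 gives 26.7%, so the step is a number 8.8 percentage points lower from compound 3 to compound 1 (within the scatter). Compound 2 `Cc1ccc(S(=O)(=O)n2cc(-c3cc(C(F)(F)F)cc(-c4cn(S(=O)(=O)c5ccc(C)cc5)c5cc(Br)ccc45)n3)c3ccc(Br)cc32)cc1` is built on a second core; the difference between the two cores is not broken down here. In this assay compound 2 gives 30.7%. Compound 4 `Cc1ccc(S(=O)(=O)n2cc(-c3cc(C(F)(F)F)c(C#N)c(-c4cn(S(=O)(=O)c5ccc(C)cc5)c5cc(Br)ccc45)n3)c3ccc(Br)cc32)cc1`, not yet measured, differs from compound 2 by cyano in place of hydrogen on an aromatic carbon, the same change with the same surroundings as before. The step from compound 2 to compound 4 is expected to be a number 6.7 percentage points lower from compound 2 to compound 4 (within the scatter), resting on a number 8.8 percentage points lower from compound 3 to compound 1 (within the scatter). Compound 4 is therefore estimated at 24% in this assay, with an expected range from 12% to 36%.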

Compound 4, a percentage reported as inhibition, at one concentration (the size of the read-out at that concentration, not a potency): 18.8%
Estimate against measurement, compound 4: 5.2 percentage points above, and the stated range covers the measured number.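

On the second core, cyano in place of hydrogen gives a number 11.9 percentage points lower from compound 2 to compound 4 (beyond the scatter) in this assay. On both cores the change lowers the number, and the two steps agree in size, so for these two cores it carries over: the same change on two cores in this assay, a number 8.8 percentage points lower (within the scatter) from compound 3 to compound 1 and a number 11.9 percentage points lower (beyond the scatter) from compound 2 to compound 4, 3.1 percentage points apart, within the scatter of two such steps This rests on just two pairs, one of whose steps lies within the scatter; it does not show that the change would act the same way on any other core, and it does not explain why the number falls.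

Only hydrogen and cyano appear at that aromatic carbon. As far as these compounds go, what an amine or a carboxylic acid in the same place would do to the inhibition stays open.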